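The compounds below may be only part of what the source reports. "The series", "measured", "known", "first", "only" and "open" are said of these compounds alone.

Measured compounds:
- compound 1 `Cn1ncnc1-c1ccccc1NCC1=NCCN1`: 63.1 nM in an in vitro functional assay on cells (Fibroblast) for agonist activity at Alpha-1D adrenergic receptor (Homo sapiens); a higher number here means that more compound is needed for the effect, a lower number that less compound is needed
- compound 2 `CCn1ncnc1-c1ccccc1NCC1=NCCN1`: 126 nM in this assay

Compound 1 holds the lowest of the two numbers; its nearest neighbour is compound 2, and the step of a 2.0-fold higher number from compound 1 to compound 2 (0.30 log units; within the scatter) lies within the scatter. Compound 3 `Cn1nccc1-c1ccccc1NCC1=NCCN1` differs from compound 1 by 1-methyl-1H-pyrazol-5-yl in place of 1-methyl-1H-1,2,4-triazol-5-yl on an aromatic carbon. Among the measured compounds shown here, no measured step concerns this ring exchange; the only step available, a 2.0-fold higher number from compound 1 to compound 2 (0.30 log units; within the scatter), touches a different part of the molecule and was within the scatter. The expected step is therefore a 1.3-fold higher number from compound 1 to compound 3 (0.10 log units; within the scatter), no change beyond the scatter. Compound 3 is estimated at 80 nM, range 25 nM to 250 nM.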

Compound 3, half-maximal effective concentration: < 100000 nM
Compound 3: a limit, no number; the forecaster's own chance of this, stated with the estimate: 5%; the middle value does not contradict the limit.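

Compound 3 gives only a limit, not a number, so the step from compound 1 to compound 3 cannot be read: the limit of < 100000 nM in this assay, at which 1 of the 3 values shown sits.

From the compounds shown here alone, whether 1-methyl-1H-pyrazol-5-yl in place of 1-methyl-1H-1,2,4-triazol-5-yl shifts the result in this assay beyond the scatter stays open.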